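A few compounds are considered here, and "the series" means these few. Any claim that something is new, unique, unknown or untested is made for them only; others in the source may bear on it.

Compounds measured in a functional assay on HeLa cells (Homo sapiens) for antiproliferative activity, read by CCK-8 assay, with a stated time of 72 h, tested at 8 uM; on this read-out lower numbers stand for a weaker effect and higher numbers for a stronger effect at the one concentration tested:
compound 1 `Nc1ccccc1NC(=O)c1ccc(CSC(=S)N2CCN(Cc3ccccn3)CC2)cc1`, compound 1 gives 61.4%
compound 2 `Nc1ccccc1NC(=O)c1ccc(CSC(=S)N2CCCc3ccccc32)cc1`, compound 2 gives 35.7%
compound 3 `Nc1ccccc1NC(=O)c1ccc(CSC(=S)N2CCc3cc(Cl)ccc32)cc1`, compound 3 gives 65.1%

Compound 3 holds the highest of the three numbers in this assay. Its nearest neighbour is compound 1, which lies within the scatter of it, so the two cannot be ranked; the furthest is compound 2, which lies beyond the scatter below it. Among the compounds with values here, only one single-point step connects the measured compounds: a number 29.4 percentage points higher from compound 2 to compound 3 (beyond the scatter).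

Compound 4 `CC1CCN(C(=S)SCc2ccc(C(=O)Nc3ccccc3N)cc2)CC1` is the next compound. Its change relative to compound 3 is
4-methylpiperidin-1-yl in place of 5-chloro-2,3-dihydro-1H-indol-1-yl on a thiocarbonyl carbon

Within the data shown here, the one measured step exchanges one fused bicyclic group for another and therefore does not directly cover a change to a single saturated ring. Among the measured compounds shown here, the only guide is compound 1, whose group on the thiocarbonyl carbon is also a single non-fused ring and whose number sits within the scatter of compound 3. Both observations point to a value that is not far from compound 3, though a group of this kind has not been tested, so a moderate fall is expected, with a wide range: a number 15.1 percentage points lower from compound 3 to compound 4 (beyond the scatter). Compound 4 is estimated at 50%, expected between 25% and 72%.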

Compound 4, a percentage reported as inhibition, at one concentration (the size of the read-out at that concentration, not a potency): 72.5%
Beside the measured number, compound 4's estimate is 22.5 percentage points below it; the whole stated range lies below it.
By their numbers in this assay, from the lowest: compound 2; then compounds 1, 3 and 4 (each within the scatter of the next, the first and the last beyond it).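

In this assay, the step from the fused 5-chloro-2,3-dihydro-1H-indol-1-yl group to the single-ring 4-methylpiperidin-1-yl group on the thiocarbonyl carbon gives a number 7.4 percentage points higher from compound 3 to compound 4 (within the scatter) and so cannot be told apart from no change. Against the 1,2,3,4-tetrahydroquinolin-1-yl group, the same single ring gives a number 36.8 percentage points higher from compound 2 to compound 4 (beyond the scatter) and shows that a fused aromatic ring is not required at this place for a read-out at the level of compound 3. Nothing in hand bears on why these groups give such different numbers.

Still open, going by these compounds, is whether the methyl of the 4-methylpiperidin-1-yl group matters, which a plain piperidin-1-yl group would test. Also open, on these data alone, is whether a ring is needed on the thiocarbonyl carbon at all, which an open-chain diethylamino group would test.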